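Changing the Benzyl Group on a Shared Core

This account rests on a few compounds, and the source may have more. Where it says the series, first, only, none or still open, it means among the compounds named here.

Three compounds built on one shared core have been measured in a functional assay on B16 cells (Mus musculus) for antiproliferative activity, read by MTT assay, with a stated time of 24 h; on this read-out lower numbers stand for stronger inhibition and higher numbers for weaker inhibition:

Compound 1 `COc1cc(OC)c(-c2coc3cc(OCc4ccc(F)cc4)ccc3c2=O)cc1OC`: 1120 nM
Compound 2 `COc1cc(OC)c(-c2coc3cc(OCc4ccc(Br)cc4)ccc3c2=O)cc1OC`: 1180 nM
Compound 3 `COc1cc(OC)c(-c2coc3cc(OCc4ccccc4C)ccc3c2=O)cc1OC`: 2150 nM

Compound 2 stands second highest of the three numbers. Its nearest neighbour is compound 1, with a 1.1-fold higher number from compound 1 to compound 2 (0.02 log units; within the scatter); its furthest is compound 3, with a 1.8-fold higher number from compound 2 to compound 3 (0.26 log units; within the scatter). Both steps lie within the scatter, so the three measured compounds cannot be told apart on these numbers.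

Compound 4 `COc1cc(OC)c(-c2coc3cc(OCc4cccc(C(F)(F)F)c4)ccc3c2=O)cc1OC` has not yet been measured. It differs from compound 2 in one place: 3-(trifluoromethyl)phenyl in place of 4-bromophenyl on a saturated chain carbon bound to an oxygen on an aromatic ring.

Two measured steps change the ring on the same saturated chain carbon, a 1.9-fold higher number from compound 1 to compound 3 (0.28 log units; within the scatter) and a 1.8-fold higher number from compound 2 to compound 3 (0.26 log units; within the scatter); a third, a 1.1-fold higher number from compound 1 to compound 2 (0.02 log units; within the scatter), swaps one halogen for another. None of them moves the number beyond the scatter. On this basis the change to compound 4 is expected to give no step beyond the scatter in this assay, in either direction. Compound 4 is therefore estimated at 1300 nM, with a range from 600 nM to 2800 nM. The expected step is a 1.1-fold higher number from compound 2 to compound 4 (0.04 log units; within the scatter).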

Compound 4, half-maximal inhibitory concentration: > 10000 nM
Compound 4: no number, only a limit (the forecaster's own chance of this, stated with the estimate: 5%); middle value at least 7.6-fold (0.88 log units) away from the limit.
By their numbers in this assay, from the lowest: compounds 1, 2 and 3 (each within the scatter of the next). At a limit, above all of these: compound 4.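

In this assay, compound 4 gives a limit and not a number: the limit of > 10000 nM in this assay, at which 1 of the 4 values shown sits.

Changing the ring on this saturated chain carbon can therefore matter, with an at least 8.4-fold higher number from compound 2 to compound 4 (0.92 log units; beyond the scatter), an at least 8.9-fold higher number from compound 1 to compound 4 (0.95 log units; beyond the scatter) and an at least 4.6-fold higher number from compound 3 to compound 4 (0.66 log units; beyond the scatter). The earlier ring changes among compounds 1, 2 and 3 all stayed within the scatter, so 3-(trifluoromethyl)phenyl is the only ring shown that moves the result beyond it.

The compounds shown do not separate the trifluoromethyl group from its place on the ring, and a 4-(trifluoromethyl)phenyl or a 3-bromophenyl ring on the same carbon would be the direct test. They also leave open how a ring carrying an amine or a carboxylic acid would behave at this position.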